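Trimming a Side Chain in a Series of Receptor Modulators

The source may hold more compounds than are shown below. What is called first, only, known or untested is meant among the compounds shown, and "the series" means these compounds.

Of the compounds shown here, three have so far been measured in an assay on HEK293 cells for positive allosteric modulation of metabotropic glutamate receptor 3 (Rattus norvegicus), read by thallium flux, with a stated time of 2.5 min; a higher number here means a larger maximal response, a lower number a smaller maximal response. Compound 1 `COc1cc(C(=O)O)ccc1OCCCCOc1ccc(C(=O)CC(C)(C)C)c(O)c1C` gives 109%, the highest of the three numbers. Compound 2 `COc1ccc(C(=O)O)cc1OCCCCOc1ccc(C(=O)CC2CCCC2)c(O)c1C` gives 67.6%, and compound 3 `COC(=O)c1ccc(OCCCCOc2ccc(C(=O)CC(C)C)c(O)c2C)cc1` gives 22.7%; both of these lie beyond the scatter below compound 1. Compound 4 `COc1cc(C(=O)O)ccc1OCCCCOc1ccc(C(C)=O)c(O)c1C` has not yet been measured. It differs from compound 1 in one place: hydrogen in place of tert-butyl on a saturated chain carbon bound to a carbonyl carbon. Among the measured compounds shown here, no measured pair in this set isolates such a change, so its direction cannot be read from the data. Cutting the chain down in this way is expected to lower the maximal response moderately, with the step estimated at a number 49 percentage points lower from compound 1 to compound 4 (beyond the scatter). Compound 4 is accordingly expected to reach about 60%, within a range from 25% to 100%.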

Compound 4, largest response reached (reported as percent of maximum), in percent of the reference or control that the assay uses: 26.3%
The estimate for compound 4 lay 33.7 percentage points above the measured number, within the range that was stated.
By their numbers in this assay, from the lowest: compounds 3 and 4 (each within the scatter of the next); then compound 2; then compound 1.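

Hydrogen in place of tert-butyl on this saturated chain carbon bound to a carbonyl carbon gives the first direct reading of this position: in this assay the change is a number 82.7 percentage points lower from compound 1 to compound 4 (beyond the scatter), a large step. On this core, then, the maximal response depends heavily on what sits at this place, and the acetyl of compound 4 does not retain the response of the neopentylcarbonyl of compound 1. Nothing available explains this loss. Still open, from the compounds shown here alone, is how the response behaves between these two extremes. An ethyl group or a phenyl ring at this place would show whether it returns gradually or depends on tert-butyl itself.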